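A few compounds are considered here, and "the series" means these few. Any claim that something is new, unique, unknown or untested is made for them only; others in the source may bear on it.

The series shares one core carrying an ester on the aromatic ring, and its members differ only in the aryl group on the carbonyl carbon. Compound 1 `CC1=CC[C@H](C(C)C)c2cc(C)c(OC(=O)c3ccc([N+](=O)[O-])cc3)cc21` bears a 4-nitrophenyl group, and in a functional assay on SK-LU-1 cells (Homo sapiens) for antiproliferative activity, read by sulforhodamine B assay, with a stated time of 48 h, tested at 50 uM (a lower number here means less inhibition, a higher number more inhibition at the concentration tested (going by the name of the read-out)), compound 1 gives 47.5%. Among the compounds with values here, compound 2 `CC1=CC[C@H](C(C)C)c2cc(C)c(OC(=O)c3cccc(Cl)c3)cc21` carries a 3-chlorophenyl group instead, and compound 2 gives 30.6%; the step of a number 16.9 percentage points lower from compound 1 to compound 2 (beyond the scatter) is the only step among the measured compounds that changes the aryl group and still yields two numbers. Compound 3 `CC1=CC[C@H](C(C)C)c2cc(C)c(OC(=O)c3cccc(C)c3)cc21` carries a 3-methylphenyl group, and for compound 3 the result is "not active" (no number reported), so no single number places it on the scale shared by compound 1 and compound 2.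

Compound 4 `CC1=CC[C@H](C(C)C)c2cc(C)c(OC(=O)c3cccc([N+](=O)[O-])c3)cc21` is the 3-nitrophenyl analogue. The change from compound 3 to compound 4 is nitro in place of methyl on an aromatic carbon. Within the data shown here, no measured step pairs a methyl with a nitro on the same ring position, so the expectation rests on the 4-nitrophenyl result of compound 1 and the 3-chlorophenyl result of compound 2. On this basis compound 4 is expected to fall between those two, near 35%, with a plausible range from 10% to 60%, and a real chance that it is again reported only as not active.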

Compound 4, a percentage reported as inhibition, at one concentration (the size of the read-out at that concentration, not a potency): 60.4%
Estimate against measurement, compound 4: 25.4 percentage points below, outside the stated range (above it).
By their numbers in this assay, from the lowest: compound 2; then compound 1; then compound 4.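

The nitro group on the 3-position of the aryl ring now gives the highest number in the series: in this assay, the exchange of 3-chlorophenyl for 3-nitrophenyl gives a number 29.8 percentage points higher from compound 2 to compound 4 (beyond the scatter), so at this ring position the choice of group changes the inhibition measurably. The earlier pair differed in both group and ring position, whereas moving the nitro group alone, from 4-nitrophenyl to 3-nitrophenyl, gives a number 12.9 percentage points higher from compound 1 to compound 4 (beyond the scatter), which shows that the place of the nitro group on the ring matters in its own right. The change from 3-methylphenyl to 3-nitrophenyl itself cannot be read as a step, since compound 3 has no number, although the two compounds lie on either side of the reported activity. Nothing available explains why the 3-nitrophenyl ester gives the larger number.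

On these data alone, it remains open whether an amine or a carboxylic acid on the same ring carbon would keep, raise or lower the inhibition at this single concentration. Also open, as far as these compounds go, is how a longer chain, such as ethyl or propyl, would compare with the methyl of compound 3.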